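Nitro in place of methoxy on compound 3

The source may hold more compounds than are shown below. What is called first, only, known or untested is meant among the compounds shown, and "the series" means these compounds.

In a functional assay on MCF7 cells (Homo sapiens) for antiproliferative activity, read by luminescence and CellTiter-Glo, with a stated time of 48 h (on this read-out higher numbers stand for weaker inhibition and lower numbers for stronger inhibition), compound 3 `COc1ccc(/C=C/[C@@H]2CC=CC(=O)O2)cc1` gives 88700 nM, the higher of the two exact numbers available. Compound 2 `O=C1C=CC[C@H](/C=C/c2ccc([N+](=O)[O-])cc2)O1` gives 28800 nM. Compound 1 `COc1ccc(/C=C/[C@H]2CC=CC(=O)O2)cc1` reads > 100000 nM, which is a limit of the assay and not a number. Compound 4 `O=C1C=CC[C@@H](/C=C/c2ccc([N+](=O)[O-])cc2)O1` follows from compound 3 by nitro in place of methoxy on an aromatic carbon. The same exchange gave an at least 3.4-fold lower number from compound 1 to compound 2 (0.54 log units; beyond the scatter), and this is the step that bears most directly. The change of configuration alone gave an at least 1.1-fold lower number from compound 1 to compound 3 (0.05 log units; that floor lies within the scatter), which sets no size for the new step. A similar move towards a lower number is therefore expected, and the expected step is a 3.4-fold lower number from compound 3 to compound 4 (0.53 log units; beyond the scatter). Compound 4 is estimated at 26000 nM, with an expected range of 10000 nM to 60000 nM.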

Compound 4, half-maximal inhibitory concentration: > 100000 nM
Compound 4: only a limit was reported; the forecaster's own chance of this, stated with the estimate: 3%; middle value at least 3.8-fold (0.58 log units) away from the limit.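

Compound 4 reads > 100000 nM, which is a limit of the assay and not a number. Nitro in place of methoxy gave an at least 1.1-fold higher number from compound 3 to compound 4 (0.05 log units; that floor lies within the scatter), so the gain seen with the other configuration did not carry over: the same change on two cores in this assay, an at least 3.4-fold lower number (0.54 log units; beyond the scatter) from compound 1 to compound 2 and an at least 1.1-fold higher number (0.05 log units; that floor lies within the scatter) from compound 3 to compound 4, at least 3.9-fold (0.59 log units) apart, beyond the scatter of two such steps Among the nitro compounds, the configuration at the saturated ring carbon separates the pair, with an at least 3.4-fold higher number from compound 2 to compound 4 (0.54 log units; beyond the scatter).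

On these data alone, the true size of the steps that end at a limit stays open: the limit of > 100000 nM in this assay, at which 2 of the 4 values shown sit. Whether an amine or a carboxylic acid on that aromatic carbon would follow compound 2 or compound 4 also stays open.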